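The source may report more compounds than this note shows. Statements on the series, on what has been measured and on what is new or still open speak of the compounds shown alone.

Series notes on the shared core of compound 1 `O=C(Nc1cccc(Oc2ccccn2)c1)C1CCCN(C(=O)c2cc(C(F)(F)F)cc(C(F)(F)F)c2)C1`. In an ADME assay on PC-3 cells (Homo sapiens) for cytotoxicity, read by WST assay, tested at 100 uM (a higher number here means more inhibition at the concentration tested (going by the name of the read-out), a lower number less inhibition), compound 1 gives 0%; compound 2 `CC(=O)Nc1cccc(C(=O)N2CCCC(C(=O)Nc3ccc(Cl)cc3)C2)c1` gives 4% and compound 3 `N#Cc1cccc(C(=O)N2CCCC(C(=O)Nc3ccc(Cl)cc3)C2)c1` gives 0%. Compound 1 thus stands level with compound 3 and within the scatter of compound 2, so all three readings sit close to zero. For the measured compounds named here, the only measured step, a number 4 percentage points lower from compound 2 to compound 3 (within the scatter), concerns a change at another position and does not bear on the present one. Compound 4 `O=C(Nc1cccc(Cc2ccccc2)c1)C1CCCN(C(=O)c2cc(C(F)(F)F)cc(C(F)(F)F)c2)C1` differs from compound 1 by benzyl in place of (pyridin-2-yl)oxy on an aromatic carbon. Going by the values given here, no measured step speaks to this change; with every reading so far near zero, the expected step is a number 2 percentage points higher from compound 1 to compound 4 (within the scatter), nothing beyond the scatter. Compound 4 is therefore estimated at 2%, within a range from 0% to 12%.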

Compound 4, a percentage reported as inhibition, at one concentration (the size of the read-out at that concentration, not a potency): 0%
Compound 4: middle estimate off by 2 percentage points, on the high side; the measured number falls inside the stated range.
By their numbers in this assay, from the lowest: compounds 1, 3, 4 and 2 (each within the scatter of the next).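

In this assay, for the compounds shown here, the change at this aromatic carbon gives no change at the digits printed from compound 1 to compound 4 (within the scatter) as the first measured step at this position. Benzyl in place of (pyridin-2-yl)oxy removes the ring nitrogen and the oxygen, yet the reading stays near zero, so neither atom is needed for so low a reading on this core. Nothing measured here offers an explanation for this flat result. Still open, as far as these compounds go, is whether another kind of group on this carbon, such as an amine or a carboxylic acid, would move the reading beyond the scatter.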